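Haloalkyl in place of ester on the oxazole side chain

The source may hold more compounds than are shown below. What is called first, only, known or untested is meant among the compounds shown, and "the series" means these compounds.

Measured so far, in an assay for inhibition of Fatty-acid amide hydrolase 1 (Rattus norvegicus), using a Dixon plot; a lower number here means a stronger inhibitor, a higher number a weaker inhibitor:
compound 1, `COCOCc1ccc(-c2cnc(C(=O)CCCCCCc3ccccc3)o2)nc1`: 10.1 nM
compound 2, `O=C(CCCCCCc1ccccc1)c1ncc(-c2ccc(CCl)cn2)o1`: 22.4 nM
compound 3, `COC(=O)CCCCc1cnc(C(=O)CCCCCCc2ccccc2)o1`: 1.8 nM

Compound 3 gives the lowest number of the three. The nearest is compound 1, with a 2.2-fold higher number from compound 1 to compound 2 (0.35 log units; beyond the scatter) separating compound 1 from compound 2 and a 12-fold lower number from compound 2 to compound 3 (1.09 log units; beyond the scatter) taking compound 2 down to compound 3.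

Compound 4, `O=C(CCCCCCc1ccccc1)c1ncc(CCCCCBr)o1`, is not yet measured. Against compound 3 the change is bromomethyl in place of methoxycarbonyl on a saturated chain carbon, four bonds along the chain from an aromatic carbon; the same difference read one bond further out is (methoxycarbonyl)methyl to 2-bromoethyl, 2-(methoxycarbonyl)ethyl to 3-bromopropyl, or 3-(methoxycarbonyl)propyl to 4-bromobutyl.

For the measured compounds named here, no measured step swaps an ester for a halogen on a chain. The closest is the step from compound 1 to compound 2, where a halogen on a saturated chain carbon replaced an oxygen-bearing group and the number rose modestly. The step from compound 2 to compound 3 involves a ring and does not read across. On that basis a modest rise in this assay is expected for compound 4, a 3.3-fold higher number from compound 3 to compound 4 (0.52 log units; beyond the scatter). The estimate for compound 4 is 6 nM, within 2.5 nM to 20 nM.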

Compound 4, inhibition constant: 6.1 nM
The estimate for compound 4 lay 1.0-fold (0.01 log units) below the measured number, and the stated range covers the measured number.
By their numbers in this assay, from the lowest: compound 3; then compounds 4 and 1 (each within the scatter of the next); then compound 2.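

In this assay the step of a 3.4-fold higher number from compound 3 to compound 4 (0.53 log units; beyond the scatter) shows that this chain end does not require the ester: with bromomethyl in its place, on a saturated chain carbon four bonds along the chain from an aromatic carbon, the number rises only modestly, even though the entering group has no hydrogen-bond acceptors. The earlier compounds shown here showed a halogen only on the group carried by the six-membered aromatic ring, and the step of a 3.7-fold lower number from compound 2 to compound 4 (0.56 log units; beyond the scatter) now adds that a halogen-bearing open chain on the same aromatic carbon gives a lower number than that ring-bearing group with its chloro end, so the halogen alone does not set the number in this assay. No measurement shown explains why the ester and the bromide differ in this way.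

The compounds shown do not separate the loss of the methoxycarbonyl group from the arrival of bromine, which a plain alkyl end, a terminal chlorine or a carboxylic acid on the same chain would address. Going by these compounds, how either end group behaves on a shorter or longer chain also remains open.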